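Hydroxy for fluoro on the pyridine amide of compound 1

A few compounds are considered here, and "the series" means these few. Any claim that something is new, unique, unknown or untested is made for them only; others in the source may bear on it.

The series shares one core and varies the acyl group on the amide. Compound 1 `O=C(Nc1c(O)cccc1-c1nc2c(C(=O)O)cccc2o1)c1ncccc1F` carries a 3-fluoropyridin-2-yl on the carbonyl carbon; in an ADME assay on L6 cells (Rattus norvegicus) for cytotoxicity (on this read-out lower numbers stand for stronger inhibition and higher numbers for weaker inhibition), compound 1 gives 204000 nM. Compound 2 `O=C(Nc1c(O)cccc1-c1nc2c(C(=O)O)cccc2o1)c1cc2ccccc2[nH]1` carries 1H-indol-2-yl in its place, and in this assay compound 2 gives 212000 nM. The single measured step is a 1.0-fold higher number from compound 1 to compound 2 (0.02 log units; within the scatter), so on the two numbers shown compound 1 stands at the lower number but is not separated from compound 2.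

Compound 3 `O=C(Nc1c(O)cccc1-c1nc2c(C(=O)O)cccc2o1)c1ncccc1O` differs from compound 1 in one place: hydroxy in place of fluoro on an aromatic carbon. Among the compounds with values here, no measured step touches this position; the step from compound 1 to compound 2 concerns the whole acyl group and does not bear on a hydroxy for fluoro exchange. The two measured numbers in this assay sit close together, which gives no ground to expect movement beyond the scatter.

The expectation for compound 3 in this assay is therefore 200000 nM, within a range of 100000 nM to 400000 nM. Read as a step, this estimate means a 1.0-fold lower number from compound 1 to compound 3 (0.01 log units; within the scatter), expected to stay within the scatter.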

Compound 3, half-maximal inhibitory concentration: 14200 nM
Estimate against measurement, compound 3: 14-fold (1.15 log units) above; measured number outside the range, below it.
By their numbers in this assay, from the lowest: compound 3; then compounds 1 and 2 (each within the scatter of the next).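

In this assay, the place on the six-membered aromatic ring with 1 nitrogen, ortho to a large group and two atoms from the ring nitrogen, proves sensitive to a one-heavy-atom exchange: hydroxy in place of fluoro gives a 14-fold lower number from compound 1 to compound 3 (1.16 log units; beyond the scatter), whereas the change of the whole acyl group in a 1.0-fold higher number from compound 1 to compound 2 (0.02 log units; within the scatter) produced no separation. The acyl comparison points the same way, with a 15-fold lower number from compound 2 to compound 3 (1.17 log units; beyond the scatter), so among the three compounds the 3-hydroxypyridin-2-yl group stands apart from both 3-fluoropyridin-2-yl and 1H-indol-2-yl, and compound 3 has the lowest number, with steps to both others beyond the scatter. Nothing measured here accounts for this shift.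

As far as these compounds go, whether the lower number is specific to hydroxy remains open, and an amine or a methoxy group at the same place would test this directly. From the compounds shown here alone, it is also open whether hydroxy at another place on the pyridine ring, or a 3-hydroxyphenyl group without the ring nitrogen, would give a comparable step from compound 1.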